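Chloro in Place of Methyl Across Two Related Cores

The source may report more compounds than this note shows. Statements on the series, on what has been measured and on what is new or still open speak of the compounds shown alone.

The study compares two related cores. Compound 1 `Cc1ccc(-c2nn(-c3ccc(Br)cc3)c(/N=C/N(C)C)c2C=O)cc1` and compound 2 `CN(C)/C=N/c1c(C=O)c(-c2ccc(Cl)cc2)nn1-c1ccc(Br)cc1` share one core; compound 3 `Cc1ccc(-c2cc(/N=C/N(C)C)n(-c3cccc(Cl)c3)n2)cc1` and compound 4 `CN(C)/C=N/c1cc(-c2ccc(Cl)cc2)nn1-c1cccc(Cl)c1` share another. The difference between the two cores is not broken down here. In a functional assay on NCI-H226 cells (Homo sapiens) for inhibition, read by MTT assay, with a stated time of 72 h (on this read-out higher numbers stand for weaker inhibition of growth and lower numbers for stronger inhibition of growth), compound 1 gives 8200 nM and compound 2 gives 62900 nM, while compound 3 gives 80900 nM. Compound 2 and compound 3 lie within the scatter of each other, and both stand beyond it from compound 1. The change from compound 1 to compound 2 is chloro in place of methyl on an aromatic carbon, and the change from compound 3 to compound 4 is chloro in place of methyl on an aromatic carbon, the same change at the same place; among the compounds shown it occurs twice. Because a 7.7-fold higher number from compound 1 to compound 2 (0.88 log units; beyond the scatter) moved toward weaker growth inhibition on the first core, a step in the same direction is expected on the second, namely a 2.5-fold higher number from compound 3 to compound 4 (0.39 log units; beyond the scatter), though the core differs and the size is uncertain. Compound 4 is therefore estimated at 200000 nM, between 60000 nM and 700000 nM, with a real chance that only a limit is reported.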

Compound 4, concentration for 50% growth inhibition: 75600 nM
Compound 4: middle estimate off by 2.6-fold (0.42 log units), on the high side; the range from low to high includes it.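

In this assay, the change from 4-methylphenyl to 4-chlorophenyl on the second core gives a 1.1-fold lower number from compound 3 to compound 4 (0.03 log units; within the scatter), so on this core the two compounds cannot be told apart. Set beside the first core, the same change does not carry over in size: the same change on two cores in this assay, a 7.7-fold higher number (0.88 log units; beyond the scatter) from compound 1 to compound 2 and a 1.1-fold lower number (0.03 log units; within the scatter) from compound 3 to compound 4, 8.2-fold (0.91 log units) apart, beyond the scatter of two such steps. This shows that, for these two pairs, a step measured on one core did not predict the step on the other, but it does not show which feature of the cores accounts for the gap, and two pairs give no rule for any further core.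

The compounds shown leave open which of the features that separate the two cores goes with the larger step, as the cores are not compared one place at a time. They also leave open how an amine, a carboxylic acid or a methoxy group in place of the methyl or the chloro would read in this assay on either core.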